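Swapping a Thiophene for a Methoxyphenyl on the Benzyl Arm

The compounds below may be only part of what the source reports. "The series", "measured", "known", "first", "only" and "open" are said of these compounds alone.

Compound 1 `COc1ccc(CN2C(=O)C(=O)c3cc(OC(F)(F)F)ccc32)cc1`: 1100 nM
Compound 2 `O=C1C(=O)N(Cc2ccc(-c3ccccc3)cc2)c2ccc(OC(F)(F)F)cc21`: 2700 nM
Compound 3 `O=C1C(=O)N(Cc2ccc(-c3ccsc3)cc2)c2ccc(OC(F)(F)F)cc21`: 2800 nM

All three share one core and differ only in the group on the benzyl ring. In a functional assay on CHO cells for agonist activity at muscarinic acetylcholine receptor M5 (Homo sapiens), read by calcium flux (on this read-out lower numbers stand for an effect already at smaller amounts and higher numbers for an effect only at larger amounts of compound), compound 3 gives the highest of the three numbers, but its gap to compound 2 is within the scatter, so the two cannot be told apart; only compound 1 is clearly set off, by a 2.5-fold higher number from compound 1 to compound 3 (0.41 log units; beyond the scatter) and a 2.5-fold higher number from compound 1 to compound 2 (0.39 log units; beyond the scatter).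

Compound 4 `COc1ccccc1-c1ccc(CN2C(=O)C(=O)c3cc(OC(F)(F)F)ccc32)cc1` carries the change (2-methoxyphenyl in place of thiophen-3-yl on an aromatic carbon). Among the measured compounds shown here, the steps that bear on it are a 1.0-fold higher number from compound 2 to compound 3 (0.02 log units; within the scatter), which shows a five-membered and a six-membered aromatic ring giving indistinguishable numbers, and a 2.5-fold higher number from compound 1 to compound 2 (0.39 log units; beyond the scatter), which shows that a methoxy alone gives a lower number than a phenyl. For the measured compounds named here, no measured compound carries a methoxy on the outer ring, so that part of the change is untested. A step of a 1.1-fold lower number from compound 3 to compound 4 (0.05 log units; within the scatter) is therefore expected, small and within the scatter. Compound 4 is estimated at 2500 nM, in a range from 900 nM to 7000 nM.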

Compound 4, half-maximal effective concentration: 3900 nM
Compound 4: the middle estimate sits 1.6-fold (0.19 log units) below what was measured, within the range that was stated.
By their numbers in this assay, from the lowest: compound 1; then compounds 2, 3 and 4 (each within the scatter of the next).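

In this assay, among the compounds shown here, adding a methoxy to the outer ring gives no readable shift: the step of a 1.4-fold higher number from compound 2 to compound 4 (0.16 log units; within the scatter) lies within the scatter, and this is the first look at that group on that ring. With a 1.4-fold higher number from compound 3 to compound 4 (0.14 log units; within the scatter) also within the scatter, compound 2, compound 3 and compound 4 cannot be told apart, while a 3.5-fold higher number from compound 1 to compound 4 (0.55 log units; beyond the scatter) lies beyond it and keeps compound 1, which has no outer ring, set off from all three. Nothing available here explains why the numbers fall this way.

Going by these compounds, it remains open whether an amine or a carboxylic acid on the outer ring would give a step beyond the scatter. Also open, on these data alone, is what a hydroxy or a chlorine would give in place of the methoxy of compound 1.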